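Replacing 4-Nitrophenyl with 2-Chloro-4-fluorophenyl

This account rests on a few compounds, and the source may have more. Where it says the series, first, only, none or still open, it means among the compounds named here.

In a functional assay on PC-3 cells (Homo sapiens) for cytotoxicity, read by MTT assay, with a stated time of 72 h (a lower number here means a stronger inhibitor, a higher number a weaker inhibitor), compound 1 `N#Cc1ccc(/C=N/NC(=O)Nc2cc3c(Nc4ccc(F)c(Cl)c4)ncnc3cc2O[C@H]2CCOC2)cc1` gives 28100 nM and compound 2 `O=C(N/N=C/c1ccc([N+](=O)[O-])cc1)Nc1cc2c(Nc3ccc(F)c(Cl)c3)ncnc2cc1O[C@H]1CCOC1` gives 33500 nM, so compound 2 stands level with compound 1. Compound 3 `O=C(N/N=C/c1ccc(F)cc1Cl)Nc1cc2c(Nc3ccc(F)c(Cl)c3)ncnc2cc1O[C@H]1CCOC1` carries 2-chloro-4-fluorophenyl in place of 4-nitrophenyl on a carbon with a double bond to nitrogen. Among the measured compounds shown here, the only measured step that bears on this is nitro in place of cyano on an aromatic carbon, a 1.2-fold higher number from compound 1 to compound 2 (0.08 log units; within the scatter), which lies within the scatter. For the measured compounds named here, no measured compound carries the entering group, so this is a weak guide. The estimated step is a 1.1-fold lower number from compound 2 to compound 3 (0.05 log units; within the scatter), with none expected beyond the scatter in this assay. For compound 3 the expected value is 30000 nM, within a range of 12000 nM to 70000 nM.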

Compound 3, half-maximal inhibitory concentration: 28400 nM
Estimate against measurement, compound 3: 1.1-fold (0.02 log units) above; low and high end bracket the measured number.
By their numbers in this assay, from the lowest: compounds 1, 3 and 2 (each within the scatter of the next).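

In this assay the change to 2-chloro-4-fluorophenyl gives a 1.2-fold lower number from compound 2 to compound 3 (0.07 log units; within the scatter) and, measured against the nitrile-bearing ring, a 1.0-fold higher number from compound 1 to compound 3 (0.00 log units; within the scatter) and so both steps stay within the scatter. On this carbon with a double bond to nitrogen, a phenyl ring carrying fluorine and chlorine therefore reads the same as one carrying nitro or nitrile. No measurement at hand explains this sameness.

On these data alone, whether it extends to a phenyl ring carrying an amine or a carboxylic acid remains open. So does whether it survives replacing the phenyl ring with a longer alkyl chain.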